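Lengthening a chain past two unreadable limits

The compounds below may be only part of what the source reports. "The series", "measured", "known", "first", "only" and "open" are said of these compounds alone.

Compound 1 `CCCCCCCn1cc(COC[C@@H]2OC[C@H](N)[C@H]2O)nn1`: > 128000 nM
Compound 2 `CCCCCCCCCn1cc(COC[C@@H]2OC[C@H](N)[C@H]2O)nn1`: > 128000 nM

In a functional assay on MCF7 cells (Homo sapiens) for antiproliferative activity, read by MTT assay, with a stated time of 48 h (a lower number here means a stronger inhibitor, a higher number a weaker inhibitor), compound 1 gives > 128000 nM, which is a limit and not a number. Compound 2 gives > 128000 nM, which is also a limit. Within the data shown here, compound 2 therefore has no number of its own, and the only other value shown is a limit too.

Compound 3 `CCCCCCCCCCCCn1cc(COC[C@@H]2OC[C@H](N)[C@H]2O)nn1` keeps the shared core and extends the same chain: propyl in place of hydrogen on a saturated chain carbon, nine bonds along the chain from an aromatic nitrogen.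

Among the measured compounds shown here, only one measured step bears on this change, a step that the two limits leave unreadable from compound 1 to compound 2. It is an extension of the same chain, but it offers no size to carry forward. The whole record so far is the limit of > 128000 nM in this assay, at which 2 of the 2 values shown sit. Since compound 2 gives only the limit > 128000 nM, any expectation is loose. A modest move towards stronger inhibition in this assay is expected, and compound 3 may well report only a limit again. The expected step is an at least 1.2-fold lower number from compound 2 to compound 3 (0.10 log units; that floor lies within the scatter). Compound 3 is estimated at 100000 nM, with an expected range from 30000 nM to 200000 nM.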

Compound 3, half-maximal inhibitory concentration: 2620 nM
Compound 3: the middle estimate sits 38-fold (1.58 log units) above what was measured, and the stated range ends above it.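

In this assay compound 3 gives 2620 nM as a true number, so lengthening this chain does reach a readable effect on the cells. Propyl in place of hydrogen, on a saturated chain carbon, nine bonds along the chain from an aromatic nitrogen, brings an at least 48-fold lower number from compound 2 to compound 3 (1.68 log units; beyond the scatter) and marks a large gain, and the same chain compared with the shortest one shows an at least 48-fold lower number from compound 1 to compound 3 (1.68 log units; beyond the scatter) for pentyl in place of hydrogen. Both sizes are only floors, the step between the two shorter chains cannot be read, and compound 3 alone stands clear of the limit: the limit of > 128000 nM in this assay, at which 2 of the 3 values shown sit.

A longer chain is the obvious open case, as these compounds cannot tell whether the number in this assay would keep falling or turn back up, or at what length between compound 2 and compound 3 a readable value first appears. Also open, going by these compounds, is how much depends on the core's own groups, for instance whether an acetamide in place of its amine would keep the effect of the long chain.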